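Swapping fluoro for methoxy at the solubility limit

A few compounds are considered here, and "the series" means these few. Any claim that something is new, unique, unknown or untested is made for them only; others in the source may bear on it.

In a physicochemical assay for solubility, in phosphate buffer, at pH 7.4 (a higher number here means a more soluble compound, a lower number a less soluble compound), compound 1 `CCOC(=O)c1c(-c2ccccc2)[nH]c2cc(OC)ccc2c1=O` gives > 100000 nM, which is a limit of the assay and not a number. Compound 2 `CCOC(=O)c1c(-c2cccc(F)c2)[nH]c2cccc(OC)c2c1=O` gives > 100000 nM, again only a limit. Compound 3 `CCOC(=O)c1c(-c2cccc(C(F)(F)F)c2)[nH]c2cc(OC)ccc2c1=O` gives a true reading of 19000 nM. Compound 4 `CCOC(=O)c1c(-c2cccc(OC)c2)[nH]c2cccc(OC)c2c1=O` has methoxy in place of fluoro on an aromatic carbon of compound 2 (methoxy in place of fluoro on an aromatic carbon). Going by the values given here, the one measured step, an at least 5.2-fold lower number from compound 1 to compound 3 (0.72 log units; beyond the scatter), brings in trifluoromethyl rather than methoxy, so it is only a loose guide. A modest fall is expected, the estimated step being an at least 1.6-fold lower number from compound 2 to compound 4 (0.22 log units; that floor lies within the scatter). For compound 4 the estimated value is 60000 nM, with an expected range from 20000 nM to 120000 nM.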

Compound 4, solubility: > 100000 nM
Compound 4: no number, only a limit; the forecaster's own chance of this, stated with the estimate: 35%; middle value at least 1.6-fold (0.22 log units) from the limit.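

Compound 2 and compound 4 each give only a limit in this assay, and the step between them, methoxy in place of fluoro, cannot be read. The compounds shown leave open whether this swap shifts the reading at all, and in which direction.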